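Extending an Ether Chain: A Small Set Compared

The source may hold more compounds than are shown below. What is called first, only, known or untested is meant among the compounds shown, and "the series" means these compounds.

Four compounds make up this set, of which three have been measured in a functional assay, with a stated time of 30 min; a higher number here means a weaker inhibitor, a lower number a stronger inhibitor. Compound 1, `CCCCCCOc1cc(OC)c(Br)cc1C(C)=O`, gives 42400000 nM in this assay. Compound 2, `CCCCCCCCOc1cc(OC)c(Br)cc1C(C)=O`, gives 39000000 nM in this assay. Compound 3, `CCCCOc1cc(OC)ccc1C(C)=O`, gives 43300000 nM in this assay, and compound 4, `CCCCCCOc1cc(OC)ccc1C(C)=O`, has not yet been measured.

The change from compound 1 to compound 2 is ethyl in place of hydrogen on a saturated chain carbon, six bonds along the chain from an oxygen on an aromatic ring. It produced a 1.1-fold lower number from compound 1 to compound 2 (0.04 log units; within the scatter). Going by the values given here, the same kind of change is the one from compound 3 to compound 4: ethyl in place of hydrogen on a saturated chain carbon, four bonds along the chain from an oxygen on an aromatic ring. The two differ in where the added ethyl sits: in compound 2 it is on a saturated chain carbon six bonds along the chain from an oxygen on an aromatic ring, in compound 4 on a saturated chain carbon four bonds along the chain from an oxygen on an aromatic ring. The difference between the core of compound 1 and the core of compound 3 is not broken down here; their values in this assay lie within the scatter of each other, as do all three measured values.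

Because the earlier step is a 1.1-fold lower number from compound 1 to compound 2 (0.04 log units; within the scatter), the step from compound 3 to compound 4 is expected to be of the same small size, namely a 1.0-fold lower number from compound 3 to compound 4 (0.01 log units; within the scatter). On that basis compound 4 is estimated at 42000000 nM in this assay, within 25000000 nM to 70000000 nM.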

Compound 4, half-maximal inhibitory concentration: 42600000 nM
Compound 4: middle estimate off by 1.0-fold (0.01 log units), on the low side; low and high end bracket the measured number.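

In this assay, adding ethyl to the chain of compound 3 gives a 1.0-fold lower number from compound 3 to compound 4 (0.01 log units; within the scatter), and hydrogen in place of bromo on an aromatic carbon gives a 1.0-fold higher number from compound 1 to compound 4 (0.00 log units; within the scatter), so neither step can be told apart from repeat measurement. Carried from one core to the other, with the ethyl placed six bonds along the chain from the ring oxygen on one core and four bonds along on the other, the change reads the same on both: the same change on two cores in this assay, a 1.1-fold lower number (0.04 log units; within the scatter) from compound 1 to compound 2 and a 1.0-fold lower number (0.01 log units; within the scatter) from compound 3 to compound 4, 1.1-fold (0.03 log units) apart, within the scatter of two such steps

Going by these compounds alone, this agreement is only between two steps too small to read, so it shows that extending the chain in this way left the number within the scatter on both cores, but it does not show that a step of measurable size would carry from one core to the other, and it gives no ranking of the compounds.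

The compounds shown leave open whether a longer chain, or an amine or a carboxylic acid in place of the ether chain, would move the number beyond the scatter in this series. On these data alone, it also remains open whether chloro or a nitrile in place of bromo on that aromatic carbon would do so.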